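Azocane in place of dimethylamino on the shared core

A few compounds are considered here, and "the series" means these few. Any claim that something is new, unique, unknown or untested is made for them only; others in the source may bear on it.

Measured so far:
Compound 1 `CC(C(=O)NCc1ccc(C(F)(F)F)nc1N(C)C)c1ccc(NS(C)(=O)=O)c(F)c1` gives 2390 nM.
Compound 2 `C[C@H](C(=O)NCc1ccc(C(F)(F)F)nc1N1CC[C@@H](OCc2ccccc2)C1)c1ccc(NS(C)(=O)=O)c(F)c1` gives 50 nM.
Compound 3 `CC(C(=O)NCc1ccc(C(F)(F)F)nc1N1CCC2(CC1)CC(C(C)(C)C)=NO2)c1ccc(NS(C)(=O)=O)c(F)c1` gives 281 nM.

All three numbers come from a functional assay on CHO-K1 cells for antagonist activity at transient receptor potential cation channel subfamily V member 1 (Homo sapiens), read by FLIPR; on this read-out higher numbers stand for weaker inhibition and lower numbers for stronger inhibition. Compound 1 stands highest of the three; the nearest is compound 3, whose number is lower by a margin beyond the scatter, and the furthest is compound 2, lower still and also beyond the scatter. Both compounds with a ring-bearing amine on the core thus give lower numbers than the open dimethylamino of compound 1.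

Compound 4 `CC(C(=O)NCc1ccc(C(F)(F)F)nc1N1CCCCCCC1)c1ccc(NS(C)(=O)=O)c(F)c1` is not yet measured. It differs from compound 1 as follows: a group of 8 heavy atoms (7 carbon, 1 nitrogen; one eight-membered non-aromatic ring with 1 hetero atom) in place of a group of 3 heavy atoms (2 carbon, 1 nitrogen; no ring), on an aromatic carbon.

Among the measured compounds shown here, since no step between measured compounds is given for this exact change, the expectation rests on what compound 2 and compound 3 show against compound 1: cyclic amines at this place go with lower numbers in this assay. A downward step is therefore expected, a 6.8-fold lower number from compound 1 to compound 4 (0.83 log units; beyond the scatter), of a size beyond the scatter but short of what compound 2 reaches. Compound 4 is estimated at 350 nM, with a range from 90 nM to 1400 nM.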

Compound 4, half-maximal inhibitory concentration: 27.8 nM
Beside the measured number, compound 4's estimate is 13-fold (1.10 log units) above it; the measured number lies below the stated range.
By their numbers in this assay, from the lowest: compounds 4 and 2 (each within the scatter of the next); then compound 3; then compound 1.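

In this assay the eight-membered ring in place of dimethylamino, on the aromatic carbon next to the ring nitrogen, gives an 86-fold lower number from compound 1 to compound 4 (1.93 log units; beyond the scatter) and so counts as a large step. The ring of compound 4 carries no further group, so at this position a low number does not depend on a benzyloxy or spiro-fused substituent of the kind seen in compound 2 and compound 3; compound 4 and compound 2 lie within the scatter of each other. No measurement shown here bears on what lies behind this step.

Still open, going by these compounds, is how the number depends on ring size, since the series offers no piperidine or azepane to set beside the eight-membered ring. Equally open, on these data alone, is whether a morpholine, with an oxygen in the ring, would hold a number close to that of compound 4 in this assay at this place.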